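Replacing pentyl on compound 3

The source may report more compounds than this note shows. Statements on the series, on what has been measured and on what is new or still open speak of the compounds shown alone.

In a functional assay on BT-474 cells (Homo sapiens) for inhibition, read by fluorescence, with a stated time of 72 h (a higher number here means a weaker inhibitor of growth, a lower number a stronger inhibitor of growth), compound 1 `COc1ccc(Cn2cnc3c(Nc4cccc(Cl)c4)nc(N[C@H]4CC[C@H](N)CC4)nc32)cc1` gives 8200 nM, compound 2 `CCCCCCn1cnc2c(Nc3cc(OC)cc(OC)c3)nc(N[C@H]3CC[C@H](N)CC3)nc21` gives 3700 nM and compound 3 `CCCCCCn1cnc2c(Nc3cccc(Cl)c3)nc(N[C@H]3CC[C@H](N)CC3)nc21` gives 5100 nM, which places compound 3 within the scatter of both others. Compound 4 `CC(C)=CCC/C(C)=C/Cn1cnc2c(Nc3cccc(Cl)c3)nc(N[C@H]3CC[C@H](N)CC3)nc21` differs from compound 3 by 2,6-dimethylhepta-1,5-dien-1-yl in place of pentyl on a saturated chain carbon bound to an aromatic nitrogen. The change is 2,6-dimethylhepta-1,5-dien-1-yl in place of pentyl, on a saturated chain carbon bound to an aromatic nitrogen. Among the measured compounds shown here, the one measured change at that place is a 1.6-fold lower number from compound 1 to compound 3 (0.21 log units; within the scatter). The change on a nitrogen on an aromatic ring is a 1.4-fold higher number from compound 2 to compound 3 (0.14 log units; within the scatter). For the measured compounds named here, neither step leaves the scatter, so no step beyond it is expected in this assay, although no measured compound carries this chain. The estimate means a 1.3-fold lower number from compound 3 to compound 4 (0.11 log units; within the scatter), an expected step within the scatter. Compound 4 is expected at 4000 nM, with an estimated range of 1500 nM to 10000 nM.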

Compound 4, concentration for 50% growth inhibition: 4300 nM
Estimate against measurement, compound 4: 1.1-fold (0.03 log units) below; the measured number falls inside the stated range.
By their numbers in this assay, from the lowest: compounds 2, 4, 3 and 1 (each within the scatter of the next, the first and the last beyond it).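

With 2,6-dimethylhepta-1,5-dien-1-yl in place of pentyl on a saturated chain carbon bound to an aromatic nitrogen, this assay shows a 1.2-fold lower number from compound 3 to compound 4 (0.07 log units; within the scatter) as its result. In place of 4-methoxyphenyl, the same chain gives a 1.9-fold lower number from compound 1 to compound 4 (0.28 log units; within the scatter) as its step, so a chain with 2 double bonds joins pentyl and 4-methoxyphenyl at this place without any step leaving the scatter. No evidence is available to explain why these groups read so alike. As far as these compounds go, whether an amine or a carboxylic acid at the end of this chain would produce a step beyond the scatter remains open, as does the effect of a much shorter chain such as methyl.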